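Removing One Methyl Group from a Weak Cytotoxic Compound

A few compounds are considered here, and "the series" means these few. Any claim that something is new, unique, unknown or untested is made for them only; others in the source may bear on it.

Compound 1, `Cc1nc(Nc2ccc(Cl)cc2)sc1C(=O)/C=C/c1ccccc1`, gives > 25000 nM in a functional assay on NCI-H460 cells (Homo sapiens) for cytotoxicity, read by MTT assay (a lower number here means a stronger inhibitor, a higher number a weaker inhibitor), which is a limit of the assay rather than a number.
Compound 2, `Cc1nc(Nc2ccccc2)sc1C(=O)/C=C/c1ccc(Cl)cc1`, gives > 25000 nM in this assay, again a limit and not a number.
Compound 3, `Cc1cccc(Nc2nc(C)c(C(=O)/C=C/c3ccccc3)s2)c1`, gives 21800 nM in this assay.

For the measured compounds named here, compound 3 therefore stands as the only compound with a measured number; the other two sit at the limit described by the limit of > 25000 nM in this assay, at which 2 of the 3 values shown sit. Going by the values given here, the one step that reaches compound 3, an at least 1.1-fold lower number from compound 1 to compound 3 (0.05 log units; that floor lies within the scatter), is too small to count, since its floor lies within the scatter.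

Compound 4, `Cc1nc(Nc2ccccc2)sc1C(=O)/C=C/c1ccccc1`, differs from compound 3 by hydrogen in place of methyl on an aromatic carbon. Among the compounds with values here, no measured step removes a methyl group in this way, so the expectation rests on the weak numbers of compound 3 and on compound 2, which carries the same anilino group and sits at the limit. A small step is expected, likely toward a weaker number, with the outcome in this assay possibly reported only as a limit; for compound 4 the estimate is 30000 nM within 12000 nM to 80000 nM, a step of a 1.4-fold higher number from compound 3 to compound 4 (0.14 log units; within the scatter).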

Compound 4, half-maximal inhibitory concentration: > 25000 nM
Compound 4 gave a limit, no number; the forecaster's own chance of this, stated with the estimate: 60%; the middle value lies beyond the limit too.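

Replacing methyl with hydrogen on the aromatic carbon gives an at least 1.1-fold higher number from compound 3 to compound 4 (0.05 log units; that floor lies within the scatter), so the methyl group of compound 3 cannot be said to change the result in this assay. The steps to compound 4 from compound 1 and from compound 2, each swapping chloro for hydrogen, cannot be read, as both ends of each step are limits. Compound 4, with neither methyl nor chloro on its outer phenyl rings, also gives a limit of the assay rather than a number: the limit of > 25000 nM in this assay, at which 3 of the 4 values shown sit.

On these data alone, whether any group on this carbon can bring a number clearly beyond the scatter remains open; a methoxy group, an amine or a carboxylic acid there would be a direct test. For the compounds shown here, also open is how the chloro compounds compare with compound 4, as their values give no size for those steps.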